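The source may report more compounds than this note shows. Statements on the series, on what has been measured and on what is new or still open speak of the compounds shown alone.

Measured so far:
compound 1 `Cc1cccc(C(=O)Nc2cccc(/C=C/C(=O)c3nc4ccccc4[nH]3)c2)c1` — 1420 nM
compound 2 `COc1ccc(C(=O)Nc2cccc(/C=C/C(=O)c3nc4ccccc4[nH]3)c2)cc1` — 4880 nM

In a functional assay on HCT-116 cells (Homo sapiens) for antiproliferative activity, read by MTT assay, with a stated time of 48 h (a higher number here means a weaker inhibitor, a lower number a stronger inhibitor), compound 2 gives the highest of the two numbers, its nearest neighbour being compound 1. Going by the values given here, the one measured step, a 3.4-fold higher number from compound 1 to compound 2 (0.54 log units; beyond the scatter), is the only guide for the step from compound 2 to compound 3 `O=C(Nc1cccc(/C=C/C(=O)c2nc3ccccc3[nH]2)c1)c1cc(Cl)cc(Cl)c1`, which introduces (3,5-dichlorophenyl in place of 4-methoxyphenyl on a carbonyl carbon). That step ran against the methoxy analogue, so the reverse direction, a lower number, is expected here: a 3.3-fold lower number from compound 2 to compound 3 (0.51 log units; beyond the scatter). Compound 3 is therefore expected to fall at about 1500 nM, in the range 500 nM to 5000 nM.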

Compound 3, half-maximal inhibitory concentration: 1650 nM
Estimate against measurement, compound 3: 1.1-fold (0.04 log units) below, and the stated range covers the measured number.
By their numbers in this assay, from the lowest: compounds 1 and 3 (each within the scatter of the next); then compound 2.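

On the carbonyl carbon, 3,5-dichlorophenyl in place of 4-methoxyphenyl recovers activity in this assay (a 3.0-fold lower number from compound 2 to compound 3 (0.47 log units; beyond the scatter)), so the higher number of compound 2 is not common to every substituted phenyl here. 3,5-Dichlorophenyl and 3-methylphenyl are not separated (a 1.2-fold higher number from compound 1 to compound 3 (0.07 log units; within the scatter)), so this position accepts either group in this assay. Nothing available explains these differences.

On these data alone, whether the 4-methoxyphenyl penalty belongs to the methoxy group or to its place on the ring remains open. So does the effect of an amine, a carboxylic acid or a longer chain at this position.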